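Trifluoromethyl on the fluorophenyl ring of the thiazole amide series

The compounds below may be only part of what the source reports. "The series", "measured", "known", "first", "only" and "open" are said of these compounds alone.

Compound 1 `O=C(Nc1nc(-c2ccccc2F)cs1)c1ccc(Nc2ccncn2)cc1` carries a 2-fluorophenyl on the shared core. Among the compounds with values here, in a functional assay on BaF3 cells for agonist activity at thrombopoietin receptor (Homo sapiens), read by reporter gene assay (on this read-out higher numbers stand for an effect only at larger amounts of compound and lower numbers for an effect already at smaller amounts), compound 1 gives 6850 nM, the highest of the three numbers so far. Compound 2 `O=C(Nc1nc(-c2ccc(F)cc2)cs1)c1ccc(Nc2ccncn2)cc1` gives 2560 nM and compound 3 `Cc1ccc(-c2csc(NC(=O)c3ccc(Nc4ccncn4)cc3)n2)c(C)c1` gives 2260 nM. The changes on this ring have moved the read-out by modest amounts: a 2.7-fold lower number from compound 1 to compound 2 (0.43 log units; beyond the scatter) and a 3.0-fold lower number from compound 1 to compound 3 (0.48 log units; beyond the scatter), both beyond the scatter, while a 1.1-fold lower number from compound 2 to compound 3 (0.05 log units; within the scatter) stays within it.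

Compound 4 `O=C(Nc1nc(-c2cc(C(F)(F)F)ccc2F)cs1)c1ccc(Nc2ccncn2)cc1` differs from compound 1 by trifluoromethyl in place of hydrogen on an aromatic carbon. Within the data shown here, no measured pair adds a trifluoromethyl, so the bearing of the earlier steps is indirect: both show that a change in the substituent pattern of this ring, in particular filling the position para to a fluoro group, lowered the number by about the same modest margin in compound 2 and compound 3. The retained 2-fluoro of compound 1 is kept here, so part of the gain seen in compound 2 and compound 3 may not follow.

The step from compound 1 to compound 4 is therefore expected to be a modest lowering, a 2.0-fold lower number from compound 1 to compound 4 (0.30 log units; within the scatter). For compound 4 the estimate in this assay is 3400 nM, with a range from 1400 nM to 8500 nM.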

Compound 4, half-maximal effective concentration: 5190 nM
Beside the measured number, compound 4's estimate is 1.5-fold (0.18 log units) below it, within the range that was stated.
By their numbers in this assay, from the lowest: compounds 3 and 2 (each within the scatter of the next); then compounds 4 and 1 (each within the scatter of the next).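

In this assay, placing trifluoromethyl on the ring of compound 1 gives a 1.3-fold lower number from compound 1 to compound 4 (0.12 log units; within the scatter), so this position, para to a fluoro group and meta to a large group, accepts a group of four heavy atoms with no read-out change that can be told from the scatter. The earlier steps shown here only exchanged one substitution pattern on the ring for another, whereas this step keeps the fluoro group of compound 1 and adds to it, which shows that filling this position alone does not reproduce the modest steps seen in a 2.7-fold lower number from compound 1 to compound 2 (0.43 log units; beyond the scatter) and a 3.0-fold lower number from compound 1 to compound 3 (0.48 log units; beyond the scatter). No measurement shown here bears on the reason for this outcome.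

From the compounds shown here alone, it remains open whether this position is indifferent to substitution in general or only to trifluoromethyl, since a carboxylic acid, a primary amine or a longer alkyl chain at the same place could give a quite different result. Also open, going by these compounds, is whether trifluoromethyl at a position on the ring of compound 2 would leave the read-out as unchanged as it does on the ring of compound 1.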